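A few compounds are considered here, and "the series" means these few. Any claim that something is new, unique, unknown or untested is made for them only; others in the source may bear on it.

Compound 2 `COc1cc(OC)c2c(=O)cc(C(=O)Nc3cccc(N4CCCC4)c3)[nH]c2c1` is one of two measured members of this set. In a functional assay on SEM cells (Homo sapiens) for antiproliferative activity, with a stated time of 72 h (on this read-out lower numbers stand for an effect already at smaller amounts and higher numbers for an effect only at larger amounts of compound), compound 2 gives only a limit, > 58600 nM, and its standing on the numbers is simply that of the limit of > 58600 nM in this assay, at which 1 of the 2 values shown sits. Compound 1 `C=CCNC(=O)n1c(-c2ccc(OC)cc2)cc(=O)c2c(OC)cc(OC)cc21`, built differently, gives 12000 nM in this assay. Compound 3 `COc1cc(OC)c2c(=O)cc(C(=O)Nc3cccc(-n4ccnc4)c3)[nH]c2c1` differs from compound 2 by 1H-imidazol-1-yl in place of pyrrolidin-1-yl on an aromatic carbon. Among the measured compounds shown here, no measured pair covers such a change, so no shift beyond the usual scatter is expected in either direction. Compound 3 is therefore estimated at 45000 nM, with a range from 12000 nM to 150000 nM, an expected step of an at least 1.3-fold lower number from compound 2 to compound 3 (0.11 log units; that floor lies within the scatter).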

Compound 3, half-maximal effective concentration: > 16300 nM
Compound 3 gave a limit, no number; the forecaster's own chance of this, stated with the estimate: 60%; the middle value lies beyond the limit too.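

Among the compounds shown here, compound 2 and compound 3 each give only a limit, not a number, in this assay, so no step between them can be read. The compounds shown leave open what 1H-imidazol-1-yl in place of pyrrolidin-1-yl actually changes in this assay.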